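A few compounds are considered here, and "the series" means these few. Any claim that something is new, unique, unknown or untested is made for them only; others in the source may bear on it.

Measured so far:
compound 1, `CCOc1cccnc1Nc1cccc(C)n1`, 40 nM
compound 2, `CCCOc1cccnc1Nc1cccc(C)n1`, 1600 nM
compound 3, `Cc1cccc(Nc2ncccc2OC(C)C)n1`, 1000 nM

In an assay on Ltk cells with metabotropic glutamate receptor 5 (Homo sapiens) as the target, read by fluorescence and calcium flux (a lower number here means a stronger inhibitor, a higher number a weaker inhibitor), compound 3 gives the second highest of the three numbers; compound 2 sits close to it, whereas compound 1 lies far below, with a 25-fold higher number from compound 1 to compound 3 (1.40 log units; beyond the scatter). Compound 4, `Cc1cccc(Nc2ncccc2OCc2ccccc2)n1`, differs from compound 3 by benzyl in place of isopropyl on an oxygen on an aromatic ring. Among the compounds with values here, the steps that bear on this are those that enlarged the group on the oxygen on the aromatic ring: a 40-fold higher number from compound 1 to compound 2 (1.60 log units; beyond the scatter) and a 25-fold higher number from compound 1 to compound 3 (1.40 log units; beyond the scatter), both large losses, while a 1.6-fold lower number from compound 2 to compound 3 (0.20 log units; within the scatter) stayed within the scatter. Benzyl is the larger group again, so a further rise of the number in this assay is expected, its size uncertain. Compound 4 is therefore estimated at 3000 nM, between 800 nM and 12000 nM, an expected step of a 3.0-fold higher number from compound 3 to compound 4 (0.48 log units; beyond the scatter).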

Compound 4, half-maximal inhibitory concentration: 870 nM
The estimate for compound 4 lay 3.4-fold (0.54 log units) above the measured number; the measured number falls inside the stated range.
By their numbers in this assay, from the lowest: compound 1; then compounds 4, 3 and 2 (each within the scatter of the next).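

In this assay the change to benzyl on the oxygen brings no further loss, with a 1.1-fold lower number from compound 3 to compound 4 (0.06 log units; within the scatter) and a 1.8-fold lower number from compound 2 to compound 4 (0.26 log units; within the scatter) both staying within the scatter. Seven carbons and an aromatic ring therefore leave the number level with those of the propyl and isopropyl compounds, and the large step remains a 22-fold higher number from compound 1 to compound 4 (1.34 log units; beyond the scatter) as the only kind of change that matters here. No measurement offered explains this level. What the compounds leave open is how a methyl on the same oxygen would compare with the ethyl of compound 1. They also leave open whether a phenethyl chain or a fluorobenzyl would stay at this level.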